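Plasma stability of ester variants on a shared core

A few compounds are considered here, and "the series" means these few. Any claim that something is new, unique, unknown or untested is made for them only; others in the source may bear on it.

Three compounds of the series have numbers in an ADME assay on a cell-free system (plasma, Homo sapiens) for metabolic stability, read by LC-MS; on this read-out higher numbers stand for a longer-lived compound and lower numbers for a shorter-lived compound. Compound 1 `CCCOC(=O)c1cccc(-c2cc(C(=O)Nc3ccncc3F)ccc2CN)c1` gives 0.317 h in this assay. Compound 2 `CCCCOC(=O)c1cccc(-c2cc(C(=O)Nc3ccncc3)ccc2CN)c1` gives 0.367 h, and compound 3 `NCc1ccc(C(=O)Nc2ccncc2)cc1-c1cccc(C(=O)OCC2CCCC2)c1` gives 0.517 h. Compound 1 has the lowest of the three numbers, but its gaps to compound 2 and to compound 3 are both within the scatter, so no order among the three can be read from this assay.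

Compound 4 `NCc1ccc(C(=O)Nc2ccncc2F)cc1-c1cccc(C(=O)OCC2CCCCO2)c1` is not yet measured. It differs from compound 1 in one place: oxan-2-yl in place of ethyl on a saturated chain carbon bound to an oxygen next to a carbonyl group. Cut one bond further out, the same change reads propyl to (oxan-2-yl)methyl on the ester.

For the measured compounds named here, one measured step bears on this change. From compound 2 to compound 3 the ester chain went from propyl to cyclopentyl on a saturated chain carbon bound to an oxygen next to a carbonyl group, and this assay moved a 1.4-fold higher number from compound 2 to compound 3 (0.15 log units; within the scatter). Enlarging the ester chain at this place therefore has no step beyond the scatter behind it in the series, and no measured pair speaks to the oxygen that enters with oxan-2-yl.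

The step of a 1.3-fold higher number from compound 1 to compound 4 (0.10 log units; within the scatter) is thus expected to stay within the scatter. Compound 4 is estimated at 0.4 h in this assay, with a range from 0.2 h to 0.8 h.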

Compound 4, half-life: 0.117 h
Beside the measured number, compound 4's estimate is 3.4-fold (0.53 log units) above it; measured number outside the range, below it.
By their numbers in this assay, from the lowest: compound 4; then compounds 1, 2 and 3 (each within the scatter of the next).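

For the compounds shown here, at the place on a saturated chain carbon bound to an oxygen next to a carbonyl group, oxan-2-yl in place of ethyl gives a 2.7-fold lower number from compound 1 to compound 4 (0.43 log units; beyond the scatter), the first step at this place in this assay to lie beyond the scatter. Bringing in a ring at this place therefore does not always leave the number within the scatter: the change to cyclopentyl gave only a 1.4-fold higher number from compound 2 to compound 3 (0.15 log units; within the scatter), while the change to oxan-2-yl, a six-membered ring with one oxygen, moved the number to a modest but readable degree. No measured evidence shown here accounts for this step.

Compound 3 and compound 4 differ in more than one place, so the shown compounds do not separate the contribution of the ring oxygen from that of ring size or the heavy atoms added. From the compounds shown here alone, a cyclohexyl group at this place on the core of compound 1 would bear on that question, and how an amine or a carboxylic acid on the ester chain would read in this assay remains open.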